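Chloro for hydrogen in a series sitting at the assay limit

A few compounds are considered here, and "the series" means these few. Any claim that something is new, unique, unknown or untested is made for them only; others in the source may bear on it.

Compound 3 `Cc1c(O)ccc2c1[C@H](Cn1cc(-c3ccccc3)nn1)[C@@]13CC(=O)[C@@](C)(CC[C@@H]21)C3` is the starting point of this step. In a functional assay on HL-60 cells (Homo sapiens) for cytotoxicity, read by MTT assay, with a stated time of 4 days (a lower number here means a stronger inhibitor, a higher number a weaker inhibitor), compound 3 gives > 20000 nM, which is a limit of the assay rather than a number. Compound 1 `COc1ccc(-c2cn(C[C@H]3c4c(ccc(O)c4C)[C@@H]4CC[C@@]5(C)C[C@]43CC5=O)nn2)cc1` gives > 20000 nM in this assay, again a limit. Compound 2 `C=C1C[C@]23C[C@@]1(O)CC[C@H]2c1ccc(O)c(C)c1[C@@H]3Cn1cc(-c2ccc(OC)cc2)nn1` likewise gives > 20000 nM in this assay, also a limit. The one step joining two of these compounds, a step that the two limits leave unreadable from compound 1 to compound 3, is therefore of unreadable size, and the limit of > 20000 nM in this assay, at which 3 of the 3 values shown sit, is all the measurements show. Compound 4 `Cc1c(O)ccc2c1[C@H](Cn1cc(-c3ccc(Cl)cc3)nn1)[C@@]13CC(=O)[C@@](C)(CC[C@@H]21)C3` carries the change (chloro in place of hydrogen on an aromatic carbon). Going by the values given here, no measured step bears readably on this change, so no step beyond the scatter can be expected in this assay. The estimated step that the limit leaves unreadable from compound 3 to compound 4 is expected to be flat. Compound 4 is expected to give 30000 nM, between 15000 nM and 100000 nM, most likely again as a limit.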

Compound 4, half-maximal inhibitory concentration: > 20000 nM
Compound 4 ended at the assay's limit; the forecaster's own chance of this, stated with the estimate: 85%; the middle value is on the limit's open side.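

The steps from compound 3 and from compound 1 to compound 4 cannot be read, because both ends of each are limits: the limit of > 20000 nM in this assay, at which 4 of the 4 values shown sit. The compounds shown leave open whether hydrogen, methoxy and chloro on this aromatic carbon differ in potency at all.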